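This account rests on a few compounds, and the source may have more. Where it says the series, first, only, none or still open, it means among the compounds named here.

Of the compounds shown here, two have so far been tested in a functional assay on P388 cells (Mus musculus) for inhibition, tested at 100 uM; a higher number here means a stronger effect of the compound at the concentration tested, a lower number a weaker effect. Compound 1 `COc1ccc2c(-c3cc(C(F)(F)F)c(C#N)c(-c4cn(S(=O)(=O)c5ccc(C)cc5)c5cc(OC)ccc45)n3)cn(S(=O)(=O)c3ccc(C)cc3)c2c1` stands lowest of the two numbers: in this assay compound 1 gives 3.8%. Among the compounds with values here, the only other measured compound, compound 2 `Cc1ccc(S(=O)(=O)n2cc(-c3cc(C(F)(F)F)ccn3)c3ccccc32)cc1`, gives 49.9% in this assay, a gap that lies beyond the usual scatter; the two structures differ in several places at once, so this comparison shows only what the two values show and explains nothing about any single change.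

Compound 3 `COc1ccc2c(-c3cc(C(F)(F)F)cc(-c4cn(S(=O)(=O)c5ccc(C)cc5)c5cc(OC)ccc45)n3)cn(S(=O)(=O)c3ccc(C)cc3)c2c1` differs from compound 1 in one place: hydrogen in place of cyano on an aromatic carbon. Within the data shown here, no pair of measured compounds carries this same change, so its effect in this assay has no precedent here. The step from compound 1 to compound 3 is expected to be small and, if anything, upward, quite possibly within the scatter. Compound 3 is therefore estimated at 10%, within a range from 0% to 35%. This estimate means an expected step of a number 6.2 percentage points higher from compound 1 to compound 3 (within the scatter).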

Compound 3, a percentage reported as inhibition, at one concentration (the size of the read-out at that concentration, not a potency): 99.9%
For compound 3 the middle estimate is 89.9 percentage points below the measured one; measured number outside the range, above it.
By their numbers in this assay, from the lowest: compound 1; then compound 2; then compound 3.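

In this assay, replacing the nitrile with hydrogen on this aromatic carbon, ortho to a trifluoromethyl group and two atoms from the ring nitrogen, gives a number 96.1 percentage points higher from compound 1 to compound 3 (beyond the scatter). The earlier comparison of compound 1 with compound 2 involved several differences at once, whereas this single change shows that the read-out at the concentration tested can depend heavily on what sits at this one position of the shared core. Nothing available explains why this swap produces a step of this size.

As far as these compounds go, with only the nitrile and hydrogen compared here, it remains open whether other groups at this position, such as a methyl group, a chlorine atom, an amine or a carboxylic acid, would give a low or a high read-out. Also open, from the compounds shown here alone, is how strong or weak the effect of compound 3 would be at other concentrations, as this read-out gives the size of the effect at a single concentration.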